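A Vinyl Group Added to the Core of Compound 1

The source may hold more compounds than are shown below. What is called first, only, known or untested is meant among the compounds shown, and "the series" means these compounds.

Compound 1 `Cc1cc(C#N)cc(C)c1Nc1ccnc(Nc2ccc(C#N)cc2)n1` is one of two closely related compounds that have so far been tested in a physicochemical assay for lipophilicity; a lower number here means a more polar compound, a higher number a more lipophilic compound. In this assay compound 1 gives 1.47, the lowest of the two numbers. Its nearest neighbour is compound 2 `Cc1cc(Br)cc(C)c1Nc1ccnc(Nc2ccc(C#N)cc2)n1`, which in this assay gives 1.79; the two differ only by a bromo in place of cyano on an aromatic carbon, and this brought a number 0.32 log units higher from compound 1 to compound 2 (beyond the scatter).

Compound 3 `C=Cc1cnc(Nc2ccc(C#N)cc2)nc1Nc1c(C)cc(C#N)cc1C` has not yet been measured. It differs from compound 1 by a single change: vinyl in place of hydrogen on an aromatic carbon. For the measured compounds named here, no measured step adds a group to the six-membered aromatic ring with two nitrogens, so nothing in the data speaks to this exact change. Going by the values given here, the one step that exists, from compound 1 to compound 2, shows that swapping one small aromatic substituent for another moved the number by a modest but real amount. Adding two carbon atoms where a hydrogen stood is expected to raise the number in this assay, with an estimated step of a number 0.63 log units higher from compound 1 to compound 3 (beyond the scatter). Compound 3 is therefore estimated at 2.1, with a likely range from 1.6 to 2.6.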

Compound 3, partition coefficient: 2.36
Beside the measured number, compound 3's estimate is 0.26 log units below it; the range from low to high includes it.
By their numbers in this assay, from the lowest: compound 1; then compound 2; then compound 3.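

Putting vinyl in place of hydrogen on this aromatic carbon gives, in this assay, a number 0.89 log units higher from compound 1 to compound 3 (beyond the scatter). This shows that the number responds to a change at this position, ortho to a large group and para to a (4-cyanophenyl)amino group. For the compounds shown here, the earlier compounds could not show this: both carry hydrogen here, and the one step between them, a number 0.32 log units higher from compound 1 to compound 2 (beyond the scatter), comes from a change elsewhere on the molecule. No measurement at hand bears on why the number moved this far.

The compounds shown leave open whether this rise is particular to vinyl or would also appear with other groups at this position, such as an ethyl group, a longer chain, an amine or a carboxylic acid. They also leave open whether adding vinyl to compound 2, which carries bromo where compound 1 carries cyano, would move the number by a similar amount.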